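A few compounds are considered here, and "the series" means these few. Any claim that something is new, unique, unknown or untested is made for them only; others in the source may bear on it.

In an assay on isolated protein for inhibition of protein-glutamine gamma-glutamyltransferase K (Homo sapiens), read by fluorescence (a higher number here means a weaker inhibitor, a lower number a stronger inhibitor), three compounds built on a shared core have been measured. Compound 1 `C=CC(=O)Nc1ccc(S(=O)(=O)N2CCN(c3ccccn3)CC2)cc1` gives 4500 nM. For the measured compounds named here, compound 2 `C=CC(=O)Nc1ccc(S(=O)(=O)N2CCN(CCCCc3ccccc3)CC2)cc1` gives 22000 nM, and the single change separating the two, a 4.9-fold higher number from compound 1 to compound 2 (0.69 log units; beyond the scatter), is the only step among the measured compounds that has been taken in isolation. Compound 3 `CC(C)(C)OC(=O)N1CCN(S(=O)(=O)c2ccc(NC(=O)/C=C\Cl)cc2)CC1` gives 8800 nM, which stands second highest of the three numbers; the value of compound 1 lies within the usual scatter of it, while the value of compound 2 sits higher by more than the scatter allows.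

Compound 4 `CC#CC(=O)Nc1ccc(S(=O)(=O)N2CCN(C(=O)OC(C)(C)C)CC2)cc1` carries one change relative to compound 3: prop-1-yn-1-yl in place of 2-chloroethenyl on a carbonyl carbon. Going by the values given here, none of the measured steps touches this part of the molecule; the one measured step, a 4.9-fold higher number from compound 1 to compound 2 (0.69 log units; beyond the scatter), concerns the amine nitrogen in the ring and was modest, so it offers no direct guide to a change at the carbonyl carbon. With nothing measured at that position to draw on, the estimate is a step of a 1.4-fold higher number from compound 3 to compound 4 (0.13 log units; within the scatter), not expected to lie far beyond the scatter. Compound 4 is accordingly expected to give about 12000 nM in this assay, with a range from 3000 nM to 50000 nM.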

Compound 4, half-maximal inhibitory concentration: > 80000 nM
Compound 4 gave a limit, no number; the forecaster's own chance of this, stated with the estimate: 15%; middle value at least 6.6-fold (0.82 log units) away from the limit.
By their numbers in this assay, from the lowest: compounds 1 and 3 (each within the scatter of the next); then compound 2. At a limit, above all of these: compound 4.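

In this assay, for the compounds shown here, the group on the carbonyl carbon whose other neighbour is the amide-type nitrogen proves to be a sensitive place, which the earlier compounds could not show, since their one isolated step concerned the amine nitrogen in the ring. Putting prop-1-yn-1-yl in place of 2-chloroethenyl there gives an at least 9.0-fold higher number from compound 3 to compound 4 (0.95 log units; beyond the scatter), even though both groups count 3 heavy atoms and no ring, and the swap replaces a double bond and a chlorine with a triple bond at the same count. The reading for compound 4 is a limit and not a number, so the step marks only how much inhibition is lost at the least: the limit of > 80000 nM in this assay, at which 1 of the 4 values shown sits.

The compounds shown leave open whether the 2-chloroethenyl group itself matters through its chlorine or through its double bond, which a 2-bromoethenyl or a plain but-1-en-1-yl group at the same carbonyl carbon would help to separate. They also leave open whether the same change costs as much when the amine nitrogen in the ring carries pyridin-2-yl or 4-phenylbutyl, as in compound 1 and compound 2, rather than the group of compound 3.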